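The source may report more compounds than this note shows. Statements on the series, on what has been measured and on what is new or still open speak of the compounds shown alone.

In a physicochemical assay for lipophilicity (on this read-out higher numbers stand for higher lipophilicity and lower numbers for lower lipophilicity), compound 1, `COc1cccc(CNCc2c(-c3nnc(SC(C)C)n3-c3ccccc3)n(C)c3ccccc23)c1`, gives 6.27, and compound 2, `CC(C)Sc1nnc(-c2c(CNc3cnccn3)c3ccccc3n2C)n1-c1ccccc1`, gives 4.22. Within the data shown here, the one step between measured compounds, a number 2.05 log units lower from compound 1 to compound 2 (beyond the scatter), exchanges the group on the amine nitrogen itself. Compound 3, `COc1ccc(CNCc2c(-c3nnc(SC(C)C)n3-c3ccccc3)n(C)c3ccc(F)cc23)cc1`, gives 6.42 in this assay, the highest of the three numbers, though its gap to compound 1 lies within the scatter, while it stands well beyond the scatter above compound 2.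

Compound 4 is `CC1CCN(Cc2c(-c3nnc(SC(C)C)n3-c3ccccc3)n(C)c3ccc(F)cc23)CC1`. The change from compound 3 is 4-methylpiperidin-1-yl in place of (4-methoxybenzyl)amino on a saturated chain carbon bound to an aromatic carbon. Among the measured compounds shown here, the single measured step only indirectly bears on this, since it swaps an aromatic group on the amine nitrogen rather than closing the amine into a ring, and it shows that a less carbon-rich substituent at this end of the molecule can lower the reading strongly. Here an aromatic ring with a methoxy group gives way to a smaller saturated ring and the donor is lost, so a modest decrease is expected, a number 0.52 log units lower from compound 3 to compound 4 (beyond the scatter). Compound 4 is therefore estimated at 5.9 in this assay, expected between 5.3 and 6.5.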

Compound 4, partition coefficient: 6.12
Beside the measured number, compound 4's estimate is 0.22 log units below it; low and high end bracket the measured number.
By their numbers in this assay, from the lowest: compound 2; then compounds 4, 1 and 3 (each within the scatter of the next).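

In this assay, 4-methylpiperidin-1-yl in place of (4-methoxybenzyl)amino on a saturated chain carbon bound to an aromatic carbon gives a number 0.30 log units lower from compound 3 to compound 4 (within the scatter). The earlier step at the amine nitrogen, a number 2.05 log units lower from compound 1 to compound 2 (beyond the scatter), had shown that this end of the molecule can move the reading well beyond the scatter. The new step shows that it need not: the aromatic ring of carbon only and the hydrogen-bond donor both leave, and a six-membered non-aromatic ring enters, yet the reading stays within the scatter.

The compounds shown leave open whether a morpholin-4-yl group or a carboxylic acid at this place would stay close to compound 4 or come nearer to compound 2, at 4.22. Nothing available accounts for the size of either step.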